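A few compounds are considered here, and "the series" means these few. Any claim that something is new, unique, unknown or untested is made for them only; others in the source may bear on it.

Compound 2 `Cc1cc(-c2cc(C)c(OC[C@@](C)(N)CC(C)C)cn2)ccn1` is the reference point for this step. In an ADME assay on microsomes from liver (Mus musculus) for metabolic stability, read by LC-MS, using NADPH, with a stated time of 10 min, tested at 0.5 uM (on this read-out higher numbers stand for a more stable compound and lower numbers for a less stable compound), compound 2 gives 72%. Compound 1 `Cc1cc(-c2ccnc(C(F)F)c2)ncc1OC[C@@](C)(N)CC(C)C` gives 80% in this assay, and compound 3 `CC(=O)Nc1cc(-c2ccc(OC[C@@H](N)CC(C)C)c(F)c2)ccn1` gives 79%. The number for compound 2 is the smallest of the three shown, but its gaps to compound 3 and to compound 1 both lie within the scatter, so the three compounds cannot be told apart on this read-out.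

Compound 4 `Cc1cc(-c2cc(Cl)c(OC[C@@](C)(N)CC(C)C)cn2)ccn1` is the next member. The change from compound 2 is chloro in place of methyl on an aromatic carbon.

Within the data shown here, the one single-place step measured so far is a number 8 percentage points lower from compound 1 to compound 2 (within the scatter), which exchanges a different group on a different ring and stays within the scatter. Among the measured compounds shown here, no measured step exchanges methyl for chloro, so there is no direct precedent for compound 4. On that basis the expected step is a number 2 percentage points lower from compound 2 to compound 4 (within the scatter), that is, nothing beyond the scatter. Compound 4 is therefore estimated at 70% in this assay, with a range from 50% to 88%.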

Compound 4, percent of the compound remaining: 71%
Beside the measured number, compound 4's estimate is 1 percentage points below it, and the stated range covers the measured number.
By their numbers in this assay, from the lowest: compounds 4, 2, 3 and 1 (each within the scatter of the next).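

In this assay the exchange on the aromatic carbon opposite the ring nitrogen gives a number 1 percentage points lower from compound 2 to compound 4 (within the scatter) and so stays within the scatter, which means that methyl and chloro cannot be told apart at this position on this read-out. The other single-place step, a number 8 percentage points lower from compound 1 to compound 2 (within the scatter) in the same assay, exchanges a different group on a different ring, so this is the only reading for this position among the compounds shown. No accompanying data bear on this result.

As far as these compounds go, whether an amine, a carboxylic acid, a nitrile or a longer chain at this position would give a step beyond the scatter stays open. Also open, from the compounds shown here alone, is whether chloro in place of methyl reads the same in compounds without the 2-methylpyridin-4-yl group.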